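A few compounds are considered here, and "the series" means these few. Any claim that something is new, unique, unknown or untested is made for them only; others in the source may bear on it.

Measured so far:
- compound 1, `O=C(/C=C1\CCc2c(F)cccc21)NC1CC1`: 126 mg/kg
- compound 2, `NC(=O)/C=C1\CCc2ccc(Cl)cc21`: 98 mg/kg
- compound 3, `NC(=O)/C=C1\CCc2ccc(F)cc21`: 56 mg/kg

All three numbers come from a functional assay on the whole organism with Mus musculus as the target; on this read-out higher numbers stand for an effect only at larger amounts of compound and lower numbers for an effect already at smaller amounts. Compound 1 stands highest of the three; its nearest neighbour is compound 2, within the scatter, while compound 3 lies beyond it. Compound 2 and compound 3 share one core and differ only in chloro in place of fluoro on an aromatic carbon, which in this assay gave a 1.8-fold higher number from compound 3 to compound 2 (0.24 log units; within the scatter). Compound 1 carries a different core, and the difference between the two cores is not broken down here.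

The unmeasured compound 4, `O=C(/C=C1\CCc2c(Cl)cccc21)NC1CC1`, is built from compound 1 by chloro in place of fluoro on an aromatic carbon. For the measured compounds named here, this is the same kind of change as the one from compound 3 to compound 2, but the surroundings are not identical: in compound 1 the substituted carbon is ortho to a fused ring and meta to a fused ring, whereas in compound 3 it is meta to a fused ring and para to a fused ring.

Going by the values given here, with only one measured instance of this change, and that one within the scatter, the expectation for compound 4 is a step of a 1.4-fold higher number from compound 1 to compound 4 (0.15 log units; within the scatter) in this assay, resting on a 1.8-fold higher number from compound 3 to compound 2 (0.24 log units; within the scatter) applied to compound 1 at 126 mg/kg. Compound 4 is accordingly estimated at 180 mg/kg, with a range from 90 mg/kg to 360 mg/kg expected.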

Compound 4, dose for half-maximal effect: 58 mg/kg
For compound 4 the middle estimate is 3.1-fold (0.49 log units) above the measured one; measured number outside the range, below it.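

In this assay, chloro in place of fluoro on an aromatic carbon, here ortho to a fused ring and meta to a fused ring, gives a 2.2-fold lower number from compound 1 to compound 4 (0.34 log units; beyond the scatter), so on this core the chloro compound needs the smaller dose. The change therefore does not carry over as a fixed step between these two cores, and the step seen on one core cannot simply be transferred to the other: the same change on two cores in this assay, a 1.8-fold higher number (0.24 log units; within the scatter) from compound 3 to compound 2 and a 2.2-fold lower number (0.34 log units; beyond the scatter) from compound 1 to compound 4, 3.8-fold (0.58 log units) apart, beyond the scatter of two such steps. This does not show which structural difference separates the two results, since the two pairs differ both in where the halogen sits and in what the amide nitrogen carries, and with one pair per core it gives no rule for a further core.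

The compounds shown leave open whether the step follows the position of the halogen or the amide, which a fluoro and chloro pair with the halogen placed as in compound 1 but with the amide of compound 3 would separate. Also open, from the compounds shown here alone, is how a bromo or methoxy group on the same aromatic carbon, or a longer chain on the amide nitrogen, would read in this assay.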